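The source may hold more compounds than are shown below. What is called first, only, known or untested is meant among the compounds shown, and "the series" means these compounds.

Compound 1 `Fc1ccccc1NCn1nc(-c2ccc3c(c2)OCCO3)oc1=S` gives 6390 nM 
Compound 2 `Fc1cccc(NCn2nc(-c3ccc4c(c3)OCCO4)oc2=S)c1` gives 6620 nM 
Compound 3 `S=c1oc(-c2ccc3c(c2)OCCO3)nn1CNc1cccc(Br)c1` gives 10800 nM 

All three numbers come from a functional assay, with a stated time of 6 min (a lower number here means a stronger inhibitor, a higher number a weaker inhibitor), and the compounds differ only in the group on the amine nitrogen. Compound 3 stands level with the other two within the scatter of repeat measurements: the gaps are a 1.6-fold higher number from compound 2 to compound 3 (0.21 log units; within the scatter) and a 1.7-fold higher number from compound 1 to compound 3 (0.23 log units; within the scatter) and both are too small to count as real differences.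

Compound 4 `Cc1ccc(NCn2nc(-c3ccc4c(c3)OCCO4)oc2=S)cc1` has not been measured yet. It carries 4-methylphenyl in place of 3-bromophenyl on an amine nitrogen. For the measured compounds named here, no measured compound has a 4-methylphenyl, and the evidence is therefore indirect. Placing 3-fluorophenyl in place of 2-fluorophenyl gave a 1.0-fold higher number from compound 1 to compound 2 (0.02 log units; within the scatter) and placing bromo in place of fluoro on an aromatic carbon gave a 1.6-fold higher number from compound 2 to compound 3 (0.21 log units; within the scatter) and neither step left the scatter. Resting on those two steps, no step beyond the scatter is expected in this assay and no direction is favoured. The expected change is a 1.4-fold lower number from compound 3 to compound 4 (0.13 log units; within the scatter) as an estimate only. For compound 4 the estimated value is 8000 nM with an expected range from 3500 nM to 18000 nM in this assay.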

Compound 4, half-maximal inhibitory concentration: 5700 nM
Compound 4: middle estimate off by 1.4-fold (0.15 log units), on the high side; measured number inside the range.
By their numbers in this assay, from the lowest: compounds 4, 1, 2 and 3 (each within the scatter of the next).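

In this assay, replacing 3-bromophenyl on the amine nitrogen with 4-methylphenyl gives a 1.9-fold lower number from compound 3 to compound 4 (0.28 log units; within the scatter), and the comparisons with the two fluorinated groups give a 1.2-fold lower number from compound 2 to compound 4 (0.06 log units; within the scatter) and a 1.1-fold lower number from compound 1 to compound 4 (0.05 log units; within the scatter). Until now, this position had carried only fluoro- or bromo-substituted phenyl groups, so the new result extends the picture to a methyl-bearing phenyl: across these four compounds, a carbon substituent in place of a halogen leaves the number within the scatter. No supporting measurement is available to explain why these groups give such similar values.

Going by these compounds, all four groups are substituted phenyl rings, so it remains open whether a group of a different kind on the amine nitrogen, such as a pyridine ring, a cyclohexyl ring or a longer chain, would move the number beyond the scatter. It is also open whether a phenyl ring bearing a carboxylic acid, an amine or a hydroxyl group would do so, since the compounds shown explore only halogen and methyl substituents.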